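A few compounds are considered here, and "the series" means these few. Any claim that something is new, unique, unknown or untested is made for them only; others in the source may bear on it.

Of the compounds shown here, two that share a core have been tested so far in a functional assay on 786-0 cells (Homo sapiens) for inhibition; on this read-out higher numbers stand for weaker inhibition of growth and lower numbers for stronger inhibition of growth. Compound 1 (`O=C(/C=C/c1cccc(O)c1)c1cccc(-n2cc(-c3ccccc3)[nH]c2=O)c1`) gives 2980 nM, and compound 2 (`COc1cc(/C=C/C(=O)c2cccc(-n3cc(-c4ccccc4)[nH]c3=O)c2)cc(OC)c1OC`) gives 1380 nM. Compound 2 thus holds the lower of the two numbers, and its gap to compound 1 lies beyond the usual scatter of repeated measurements, so compound 2 is the stronger growth inhibitor of this pair.

Compound 3 (`COc1ccc(-c2cn(-c3cccc(C(=O)/C=C/c4cc(OC)c(OC)c(OC)c4)c3)c(=O)[nH]2)cc1`) differs from compound 2 in one place: methoxy in place of hydrogen on an aromatic carbon. A methoxy stands in place of hydrogen on an aromatic carbon, para to a large group, turning phenyl into 4-methoxyphenyl. Among the measured compounds shown here, no measured pair yet shows what this change does in this assay, so the expectation rests on little. A step no larger than the usual scatter is expected, with only a slight lean towards a lower number, meaning stronger inhibition. Expressed as a step, the estimate is a 1.3-fold lower number from compound 2 to compound 3 (0.10 log units; within the scatter). The estimated value for compound 3 is 1100 nM, with a range from 400 nM to 3000 nM.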

Compound 3, concentration for 50% growth inhibition: 1610 nM
Beside the measured number, compound 3's estimate is 1.5-fold (0.17 log units) below it; the measured number falls inside the stated range.
By their numbers in this assay, from the lowest: compounds 2, 3 and 1 (each within the scatter of the next, the first and the last beyond it).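

Among the compounds shown here, this is the first pair that isolates a single change, and in this assay replacing hydrogen with methoxy, which turns phenyl into 4-methoxyphenyl, gives a 1.2-fold higher number from compound 2 to compound 3 (0.07 log units; within the scatter) and so leaves no readable difference between the two compounds. At this aromatic carbon, para to a large group, the added methoxy therefore comes with no measurable loss of growth inhibition, so the position can carry this small group while the compound stays in the same range of activity. Nothing at hand explains this outcome, and a single pair cannot show whether the same would hold for the rest of the series.

What the compounds shown leave open is whether this position stays just as indifferent to groups of another kind, such as an amine, a carboxylic acid or a longer chain like butoxy, any of which could move the number well beyond the scatter or leave it where it is. They also leave open whether methoxy would give the same result on a compound with a different substitution on its other aromatic ring, such as the hydroxy-bearing ring of compound 1.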